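From trifluoromethyl to chloro at the limit of the assay

This account rests on a few compounds, and the source may have more. Where it says the series, first, only, none or still open, it means among the compounds named here.

In a functional assay on MCF7 cells (Homo sapiens) for antiproliferative activity, read by MTT assay, with a stated time of 48 h (a lower number here means a stronger inhibitor, a higher number a weaker inhibitor), compound 1 (`O=C(CN1CCCCC1)Nc1ccc2ncnc(Nc3cccc(C(F)(F)F)c3)c2c1`) gives > 100000 nM as a limit and not a number. Compound 2 (`CN1CCN(CC(=O)Nc2ccc3ncnc(Nc4cccc(C(F)(F)F)c4)c3c2)CC1`) gives > 100000 nM as a limit too. Compound 3 (`O=C(CN1CCCC1)Nc1ccc2ncnc(Nc3cccc(Cl)c3)c2c1`), which carries 3-chlorophenyl, gives > 100000 nM as a limit as well. Compound 1 therefore has no exact place in the series, which offers only the limit of > 100000 nM in this assay, at which 3 of the 3 values shown sit, and no exact number.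

Compound 4 (`O=C(CN1CCCCC1)Nc1ccc2ncnc(Nc3cccc(Cl)c3)c2c1`) has chloro in place of the trifluoromethyl of compound 1 on an aromatic carbon (chloro in place of trifluoromethyl on an aromatic carbon). Among the compounds with values here, the one measured step that the two limits leave unreadable from compound 1 to compound 2 has no readable size and concerns a different group, so it gives no measure for this change. Within the data shown here, compound 3 is the only guide, and its value of > 100000 nM is a limit with the entering group already present. No change beyond the scatter is therefore expected, and the estimated a number no higher from compound 1 to compound 4 (the limit leaves the size open) has no favoured direction. For compound 4 the estimate is 100000 nM with an expected range from 30000 nM to 300000 nM and a limit is the most likely report.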

Compound 4, half-maximal inhibitory concentration: > 100000 nM
Compound 4 was reported as a limit; the forecaster's own chance of this, stated with the estimate: 80%; the middle value sits exactly at the limit.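

Compound 4 joins compounds 1 and 3 at a limit and not a number, so neither of its steps from compound 1 and compound 3 can be read: the limit of > 100000 nM in this assay, at which 4 of the 4 values shown sit.

The compounds shown leave open whether chloro and trifluoromethyl, or the piperidin-1-yl and pyrrolidin-1-yl groups, differ at all in this assay.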